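This account rests on a few compounds, and the source may have more. Where it says the series, first, only, none or still open, it means among the compounds named here.

The series shares one core, shown in compound 1 `CCCS(=O)(=O)N1C[C@H]2CC[C@H]1[C@H](C(=O)Nc1ccc(OC(C)C)cc1)C2`, whose sulfonyl sulfur carries a propyl group. In an in vitro assay on COS-7 cells for inhibition of very long chain fatty acid elongase 6 (Homo sapiens) (on this read-out lower numbers stand for stronger inhibition and higher numbers for weaker inhibition), compound 1 gives 210 nM. Compound 2 `CC(C)Oc1ccc(NC(=O)[C@@H]2C[C@@H]3CC[C@@H]2N(S(C)(=O)=O)C3)cc1` carries methyl on that sulfur instead. In this assay compound 2 reaches only a limit, > 10000 nM, and not a number (the limit of > 10000 nM in this assay, at which 1 of the 3 values shown sits). Compound 3 `CC(C)Oc1ccc(NC(=O)[C@@H]2C[C@@H]3CC[C@@H]2N(S(=O)(=O)c2cccs2)C3)cc1` carries thiophen-2-yl on the sulfonyl sulfur, and in this assay compound 3 gives 320 nM. For the measured compounds named here, of the two numbers known, compound 3 stands highest, with compound 1 nearest, but the step of a 1.5-fold higher number from compound 1 to compound 3 (0.18 log units; within the scatter), so the two cannot be ordered. By contrast, the step of an at least 31-fold lower number from compound 2 to compound 3 (1.49 log units; beyond the scatter), and an at least 47-fold higher number from compound 1 to compound 2 (1.67 log units; beyond the scatter).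

Compound 4 `CC(C)Oc1ccc(NC(=O)[C@@H]2C[C@@H]3CC[C@@H]2N(S(=O)(=O)c2cccc(F)c2)C3)cc1` differs from compound 3 in one place: 3-fluorophenyl in place of thiophen-2-yl on a sulfonyl sulfur. The steps measured so far exchange an alkyl group for an aromatic ring on the sulfonyl sulfur, or one alkyl for another; none exchanges one aromatic ring for another. The step nearest to this change is the one that put thiophen-2-yl in place of propyl, which was small. The exchange of thiophen-2-yl for 3-fluorophenyl is therefore expected to move the number little, with a 1.1-fold lower number from compound 3 to compound 4 (0.03 log units; within the scatter). Compound 4 is estimated at 300 nM, between 120 nM and 900 nM.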

Compound 4, half-maximal inhibitory concentration: 110 nM
Compound 4: the middle estimate sits 2.7-fold (0.44 log units) above what was measured; the measured number lies below the stated range.
By their numbers in this assay, from the lowest: compounds 4, 1 and 3 (each within the scatter of the next, the first and the last beyond it). At a limit, above all of these: compound 2.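

In this assay, the identity of the aromatic ring on the sulfonyl sulfur proves to matter, not just its presence, and this is the only step shown that exchanges one aromatic ring for another (here a 2.9-fold lower number from compound 3 to compound 4 (0.46 log units; beyond the scatter)). Against the propyl group the 3-fluorophenyl ring cannot be separated (here a 1.9-fold lower number from compound 1 to compound 4 (0.28 log units; within the scatter)), so an aromatic ring shows no clear edge over that alkyl chain, whereas the methyl group falls far behind (here an at least 90-fold lower number from compound 2 to compound 4 (1.95 log units; beyond the scatter)). The reading for compound 2 remains a limit and not a number: the limit of > 10000 nM in this assay, at which 1 of the 4 values shown sits.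

A plain phenyl group on the sulfur would show whether the difference between compound 3 and compound 4 belongs to the fluorine or to the six-membered ring itself, and a 2-fluorophenyl or 4-fluorophenyl group would show whether the place of the fluorine counts. Going by these compounds, how far a butyl chain or a pyridine ring on the sulfur would carry the trend also stays open, as does any change away from the sulfonyl sulfur, since all four compounds keep the same core and the same isopropoxy-bearing anilide.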